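A New Aryl Group on the Ring Amine Nitrogen

This account rests on a few compounds, and the source may have more. Where it says the series, first, only, none or still open, it means among the compounds named here.

Of the compounds shown here, three of one series have been tested in a functional assay on HL-60 cells (Homo sapiens) for inhibition, read by MTT assay, with a stated time of 72 h; on this read-out lower numbers stand for stronger inhibition and higher numbers for weaker inhibition. Compound 1 `Cc1nc(-c2ccccc2)c(C(=O)N2CCN(c3c(C)cccc3C)CC2)o1` gives 146 nM in this assay. Compound 2 `CCc1nc(-c2ccccc2F)c(C(=O)N2CCN(c3cccc(OC)c3)CC2)o1` gives 607 nM in this assay, and compound 3 `COc1ccc(-c2nc(C)oc2C(=O)N2CCN(c3cccc(Cl)c3)CC2)cc1OC` is reported as "not active" (no number reported) in this assay, with no number attached. Among the two numbers compound 1 therefore stands lowest, and its gap to compound 2 lies beyond the scatter of repeated measurements.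

Compound 4 `CC(=O)Nc1cccc(N2CCN(C(=O)c3oc(C)nc3-c3ccccc3)CC2)c1` has not yet been measured. It differs from compound 1 in one place: 3-acetamidophenyl in place of 2,6-dimethylphenyl on an amine nitrogen in a ring. Among the compounds with values here, no pair of measured compounds that differ in a single place is available, so the size of this step cannot be read from a direct comparison. What the data show is that the two compounds carrying a different group on that amine nitrogen, compound 2 and compound 3, give weaker or no inhibition compared with compound 1, though each also differs from compound 1 elsewhere. The expectation is therefore a loss of potency beyond the scatter, with the step of a 4.1-fold higher number from compound 1 to compound 4 (0.61 log units; beyond the scatter) estimated as moderate. Compound 4 is expected to give about 600 nM in this assay, within a range from 150 nM to 2500 nM, and there is a real chance that only a limit is reported.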

Compound 4, half-maximal inhibitory concentration: 329 nM
Estimate against measurement, compound 4: 1.8-fold (0.26 log units) above; low and high end bracket the measured number.
By their numbers in this assay, from the lowest: compound 1; then compounds 4 and 2 (each within the scatter of the next).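

Within the data shown here, with only the group on the amine nitrogen in the ring changed, this assay gives a 2.3-fold higher number from compound 1 to compound 4 (0.35 log units; beyond the scatter), the first direct reading of a change at this position. The loss is modest, so inhibition survives when 2,6-dimethylphenyl gives way to 3-acetamidophenyl, a larger group that brings in a hydrogen-bond donor and a hydrogen-bond acceptor. No measurement shown here accounts for the size of this step.

Going by these compounds, the change removes the two methyl groups and adds an acetamido group in a single move, so the share of each in the step remains unknown, and compound 2 and compound 3 cannot settle it, as each differs from compound 1 in more than one place. Plain phenyl, 3-aminophenyl or cyclohexyl on the same nitrogen would help to separate the two parts, and how any of them would compare with 2,6-dimethylphenyl and 3-acetamidophenyl remains open.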